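Methyl-to-chloro swap on the side-chain phenyl ring

A few compounds are considered here, and "the series" means these few. Any claim that something is new, unique, unknown or untested is made for them only; others in the source may bear on it.

Measured in an assay on LX2 cells for inhibition of COL1A1 promoter (Homo sapiens), read by a luciferase reporter, with a stated time of 24 h, tested at 20 uM; a higher number here means a stronger effect of the compound at the concentration tested, a lower number a weaker effect:
Compound 1 `Cc1ccc(-n2cc(C(=O)Nc3cc(F)cc(F)c3)c(=O)c3ccc(N(C)C)nc32)cc1OCCCCCCC[N+]12CCN(CC1)CC2` gives 5.07%.
Compound 2 `CN(C)c1ccc2c(=O)c(C(=O)Nc3cc(F)cc(F)c3)cn(-c3ccc(Cl)c(OCCCCCCC[N+]45CCN(CC4)CC5)c3)c2n1` gives 8.08%.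
Compound 3 `Cc1cc(OCCCCCCC[N+]2(C)CCCC2)ccc1-n1cc(C(=O)Nc2cc(F)cc(F)c2)c(=O)c2ccc(N(C)C)nc21` is reported as "not active" (no number reported), with no number.

The change chloro in place of methyl on an aromatic carbon moves the read-out a number 3 percentage points higher from compound 1 to compound 2 (within the scatter), so the pair hardly separates. Compound 4 `CN(C)c1ccc2c(=O)c(C(=O)Nc3cc(F)cc(F)c3)cn(-c3ccc(OCCCCCCC[N+]4(C)CCCC4)cc3Cl)c2n1` carries the same kind of change relative to compound 3, (chloro in place of methyl on an aromatic carbon); the surroundings differ in that the ring carbon is para to a large group in the first pair but meta to a large group in the second. The difference between the cores of compound 3 and compound 1 is not broken down here.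

Since compound 3 gave no number in this assay and the same kind of change left compound 1 and compound 2 within the scatter, compound 4 is expected to stay weak, estimated at 5%. The estimated range for compound 4 is -5% to 15%, with a fair chance that only inactivity is reported.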

Compound 4, a percentage reported as inhibition, at one concentration (the size of the read-out at that concentration, not a potency): "not active" (no number reported)
Nothing numeric was reported for compound 4, so the estimate cannot be set against anything.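

Compound 3 and compound 4 both lack a number in this assay, so no step can be read between them. No evidence bears on this result. The compounds shown leave open whether chloro in place of methyl alters the read-out on this side-chain type.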